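This account rests on a few compounds, and the source may have more. Where it says the series, first, only, none or still open, it means among the compounds named here.

Working notes on the series, read in a functional assay on U-937 cells (Homo sapiens) for inhibition, read by MTT assay, with a stated time of 24 h; on this read-out lower numbers stand for stronger inhibition of growth and higher numbers for weaker inhibition of growth. Compound 1 (`O=C1CC(c2cccc(NC(=O)c3ccc(Cl)c(C(F)(F)F)c3)c2)=Nc2cnn(Cc3ccccc3)c2N1`) gives 60 nM. Compound 2 (`O=C1CC(c2ccc(NC(=O)c3ccc(Cl)c(C(F)(F)F)c3)cc2)=Nc2cnn(Cc3ccccc3)c2N1`) gives 60 nM, level with compound 1 within the scatter. Compound 3 (`Cc1cn(-c2cc(C(=O)Nc3ccc(C4=Nc5cnn(Cc6ccccc6)c5NC(=O)C4)cc3)cc(C(F)(F)F)c2)cn1`) gives > 30000 nM, which is a limit and not a number. Compound 4 (`O=C1CC(c2ccc(NC(=O)Nc3ccc(Cl)c(C(F)(F)F)c3)cc2)=Nc2cnn(Cc3ccccc3)c2N1`) differs from compound 2 by (4-chloro-3-(trifluoromethyl)phenyl)amino in place of 4-chloro-3-(trifluoromethyl)phenyl on a carbonyl carbon. Within the data shown here, no measured pair shows this kind of change, so the expectation is loose: no step beyond the scatter, with any drift towards weaker inhibition of growth. The estimated step is a 1.5-fold higher number from compound 2 to compound 4 (0.18 log units; within the scatter). The expected value for compound 4 is 90 nM, with an estimated range of 20 nM to 500 nM.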

Compound 4, concentration for 50% growth inhibition: 8680 nM
The estimate for compound 4 lay 96-fold (1.98 log units) below the measured number; measured number above the stated range.
By their numbers in this assay, from the lowest: compounds 1 and 2 (each within the scatter of the next); then compound 4. At a limit, above all of these: compound 3.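

On the carbonyl carbon whose other neighbour is the amide-type nitrogen, (4-chloro-3-(trifluoromethyl)phenyl)amino in place of 4-chloro-3-(trifluoromethyl)phenyl is far from neutral in this assay: a 140-fold higher number from compound 2 to compound 4 (2.16 log units; beyond the scatter). Among these compounds, this is the first step between compounds that differ in one place, and it shows that the group on this carbonyl carbon matters greatly. Nothing at hand accounts for the size of this step.

As far as these compounds go, it remains open whether a methylene or an oxygen link in place of the amino link would give a similar step. Also open, from the compounds shown here alone, is whether the same change on compound 1 would give a step of similar size.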